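From Nitro to Sulfamoyl on the Shared Core

The source may report more compounds than this note shows. Statements on the series, on what has been measured and on what is new or still open speak of the compounds shown alone.

Compound 2 `N#CC1CN1C(=O)Nc1ccc([N+](=O)[O-])cc1` gives 9100 nM in a functional assay on RPMI-8226 cells (Homo sapiens) for inhibition (on this read-out higher numbers stand for weaker inhibition and lower numbers for stronger inhibition), the second highest of the three numbers shown. Compound 1 `N#CC1CN1C(=O)Nc1ccc(F)cc1` gives 5000 nM in this assay, and compound 3 `CCNC(=O)N1CC1C#N` gives 22000 nM. Among the compounds with values here, the only measured change at the same aromatic carbon is a 1.8-fold higher number from compound 1 to compound 2 (0.26 log units; within the scatter), and it lies within the scatter. Compound 4 `N#CC1CN1C(=O)Nc1ccc(S(N)(=O)=O)cc1` differs from compound 2 by sulfamoyl in place of nitro on an aromatic carbon. Within the data shown here, no measured pair exchanges nitro for sulfamoyl, and the one step that bears on this position is small, so the step is expected to be a 1.0-fold lower number from compound 2 to compound 4 (0.00 log units; within the scatter), nothing beyond the scatter in this assay. Compound 4 is therefore estimated at 9000 nM, with a range from 3000 nM to 27000 nM.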

Compound 4, half-maximal inhibitory concentration: > 38000 nM
Compound 4: only a limit was reported (the forecaster's own chance of this, stated with the estimate: 15%); middle value at least 4.2-fold (0.62 log units) away from the limit.
By their numbers in this assay, from the lowest: compounds 1 and 2 (each within the scatter of the next); then compound 3. At a limit, above all of these: compound 4.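

Compound 4 gives > 38000 nM in this assay as a limit of the assay and not a number. This aromatic carbon does respond to what it carries: sulfamoyl in place of nitro gives an at least 4.1-fold higher number from compound 2 to compound 4 (0.62 log units; beyond the scatter) and sulfamoyl in place of fluoro gives an at least 7.6-fold higher number from compound 1 to compound 4 (0.88 log units; beyond the scatter) and both lie beyond the scatter, whereas nitro in place of fluoro stayed within it. Going by these compounds, the true size of both steps stays unknown behind the limit.

The compounds shown leave open whether an amine or a carboxylic acid on the same carbon would stay close to compound 1 or weaken inhibition as sulfamoyl does.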